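This account rests on a few compounds, and the source may have more. Where it says the series, first, only, none or still open, it means among the compounds named here.

Notes on the series. Compound 1 `COc1ccc(-c2cnc(NC(=O)c3ccc(O)cc3)n2C)cc1` stands in a toxicity assay on THP-1 cells (Homo sapiens) for inhibition (a higher number here means that more compound is tolerated, a lower number that less compound is tolerated), only as a limit: compound 1 gives > 100000 nM, which is a limit of the assay rather than a number. Within the data shown here, the one neighbour differing in a single place is compound 2 `COc1ccc(-c2cnc(NC(=O)c3ccc([N+](=O)[O-])cc3)n2C)cc1`, and in this assay compound 2 gives > 100000 nM, again a limit. The step that the two limits leave unreadable from compound 1 to compound 2 therefore has no readable size, both values sitting at the limit of > 100000 nM in this assay, at which 2 of the 2 values shown sit.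

Compound 3 `COc1ccc(-c2cnc(NC(=O)c3ccn[nH]3)n2C)cc1` differs from compound 1 by 1H-pyrazol-5-yl in place of 4-hydroxyphenyl on a carbonyl carbon. Among the measured compounds shown here, no measured step bears on this change; the single step in hand, nitro in place of hydroxy, is itself unreadable. With both values resting at the limit of > 100000 nM in this assay, at which 2 of the 2 values shown sit, no shift beyond the scatter can be read in either direction, so compound 3 is expected to reach the limit as well. Compound 3 is estimated at 150000 nM in this assay, with a range of 50000 nM to 500000 nM. The expected step is a step that the limit leaves unreadable from compound 1 to compound 3.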

Compound 3, half-maximal cytotoxic concentration: > 100000 nM
Compound 3: no number, only a limit; the forecaster's own chance of this, stated with the estimate: 85%; the middle value does not contradict the limit.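

In this assay compound 3 gives > 100000 nM, which is a limit and not a number. Among these compounds, no step from compound 1 to compound 3 can be read: the limit of > 100000 nM in this assay, at which 3 of the 3 values shown sit.

The compounds shown leave open how much of each is tolerated beyond that limit, and whether any change on the carbonyl carbon would give a readable value.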